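A few compounds are considered here, and "the series" means these few. Any claim that something is new, unique, unknown or untested is made for them only; others in the source may bear on it.

Measured compounds:
compound 1 `N[C@@H]1CCN(c2cc3c(cc2F)c(=O)c(C(=O)O)cn3Cc2ccc(-c3ccccc3)cc2)C1`: 63600 nM
compound 2 `COc1c(N2CC[C@@H](N)C2)c(F)cc2c(=O)c(C(=O)O)cn(Cc3ccc(-c4ccccc4)cc3)c12`: 92200 nM

Among the compounds with values here, in an assay on isolated protein for inhibition of DNA topoisomerase 1 (Homo sapiens), with a stated time of 15 min (a higher number here means a weaker inhibitor, a lower number a stronger inhibitor), compound 1 and compound 2 lie within the scatter of each other, the only step between them being a 1.4-fold higher number from compound 1 to compound 2 (0.16 log units; within the scatter). Compound 2 therefore stands on the same level as compound 1; nothing separates the two.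

Compound 3 `COc1c(NCCN)c(F)cc2c(=O)c(C(=O)O)cn(Cc3ccc(-c4ccccc4)cc3)c12` arises from compound 2 by the change ((2-aminoethyl)amino in place of 3-aminopyrrolidin-1-yl on an aromatic carbon). Within the data shown here, no measured step bears on this exchange: the single step that exists concerns methoxy against hydrogen on an aromatic carbon and says nothing about replacing the ring amine with the chain amine. With no guidance beyond the level of compound 2 itself, the expected step is a 1.1-fold higher number from compound 2 to compound 3 (0.04 log units; within the scatter), that is none beyond the scatter. Compound 3 is accordingly estimated at 100000 nM in this assay, within a range of 30000 nM to 350000 nM.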

Compound 3, half-maximal inhibitory concentration: > 200000 nM
Compound 3 ended at the assay's limit; the forecaster's own chance of this, stated with the estimate: 25%; middle value at least 2.0-fold (0.30 log units) from the limit.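

Compound 3 gives > 200000 nM in this assay, which is a limit of the assay and not a number: the limit of > 200000 nM in this assay, at which 1 of the 3 values shown sits.

Putting (2-aminoethyl)amino in place of 3-aminopyrrolidin-1-yl, on the aromatic carbon ortho to a fluoro group and ortho to a methoxy group, gives an at least 2.1-fold higher number from compound 2 to compound 3 (0.33 log units; beyond the scatter). This shows that the group at this position matters in a way the methoxy exchange could not show, since that step, a 1.4-fold higher number from compound 1 to compound 2 (0.16 log units; within the scatter), stays within the scatter, and the true size of the new step remains hidden behind the limit.

Whether the ring, the defined stereocentre or the hydrogen-bond donor count accounts for the difference cannot be told from this single exchange. From the compounds shown here alone, how a piperazin-1-yl group or a longer chain such as (3-aminopropyl)amino would stand at this position remains open.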